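The compounds below may be only part of what the source reports. "The series", "measured", "known", "first", "only" and "open" are said of these compounds alone.

Measured compounds:

Compound 1, `CCn1cc(-c2nc3ccccc3o2)c(=O)c2cc(F)c(N3CCNC(C)C3)c(F)c21`: 18900 nM
Compound 2, `CCn1cc(-c2nc3ccccc3s2)c(=O)c2cc(F)c(N3CCNC(C)C3)c(F)c21`: 24300 nM
Compound 3, `CCn1cc(-c2nc3ccc([N+](=O)[O-])cc3o2)c(=O)c2cc(F)c(N3CCNC(C)C3)c(F)c21`: 600 nM

The three measured compounds share one core and differ at two places. In a functional assay on KB cells (Homo sapiens) for cytotoxicity, read by MTT assay, with a stated time of 48 h (on this read-out higher numbers stand for weaker inhibition and lower numbers for stronger inhibition), compound 1 gives 18900 nM. Compound 2 differs from compound 1 in the group attached to the core: 1,3-benzothiazol-2-yl in place of 1,3-benzoxazol-2-yl on an aromatic carbon. On this exchange the step is a 1.3-fold higher number from compound 1 to compound 2 (0.11 log units; within the scatter), so compounds 1 and 2 cannot be told apart in this assay. Compound 3 carries a further group on the ring system that compound 1 bears: nitro in place of hydrogen on an aromatic carbon. Here the step is a 32-fold lower number from compound 1 to compound 3 (1.50 log units; beyond the scatter), and compound 3 gives 600 nM, the only number among the three that stands apart beyond the scatter.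

Compound 4, `CCn1cc(-c2nc3ccc([N+](=O)[O-])cc3s2)c(=O)c2cc(F)c(N3CCNC(C)C3)c(F)c21`, has not yet been measured. Its relation to compound 2 is nitro in place of hydrogen on an aromatic carbon, the same change as that from compound 1 to compound 3: the place descriptions are identical word for word, so this is the same change on the core of compound 2. In this assay, among the measured compounds shown here, the expectation for compound 4 rests on the single earlier instance of the change, namely a 32-fold lower number from compound 1 to compound 3 (1.50 log units; beyond the scatter), and on compound 2 giving 24300 nM; compound 4 is therefore expected to show a step of a 30-fold lower number from compound 2 to compound 4 (1.48 log units; beyond the scatter). For the measured compounds named here, the estimate for compound 4 is 800 nM, with a range from 300 nM to 2500 nM expected, since only one earlier example of the change is available and it stands on a different core.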

Compound 4, half-maximal inhibitory concentration: 4700 nM
The estimate for compound 4 lay 5.9-fold (0.77 log units) below the measured number, outside the stated range (above it).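

In this assay, nitro in place of hydrogen on an aromatic carbon again lowers the number when carried to the core of compound 2, with a 5.2-fold lower number from compound 2 to compound 4 (0.71 log units; beyond the scatter), so the direction of the change holds across both available pairs. Its size does not hold, and the two steps stand clearly apart: the same change on two cores in this assay, a 32-fold lower number (1.50 log units; beyond the scatter) from compound 1 to compound 3 and a 5.2-fold lower number (0.71 log units; beyond the scatter) from compound 2 to compound 4, 6.1-fold (0.78 log units) apart, beyond the scatter of two such steps. This shows that, in this series, the step seen on one core cannot be carried over as a number to the other, even though the exchange of 1,3-benzoxazol-2-yl for 1,3-benzothiazol-2-yl alone gives only a 1.3-fold higher number from compound 1 to compound 2 (0.11 log units; within the scatter); with just two pairs, it does not show why the size differs or whether the lower number would recur on any further core.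

The compounds shown leave open whether another group on that same aromatic carbon, such as an amine, a nitrile or a carboxylic acid, would also lower the number and would differ in the same way between the two cores. They also leave open how nitro would behave on another carbon of that six-membered aromatic ring.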